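The source may report more compounds than this note shows. Statements on the series, on what has been measured and on what is new or still open speak of the compounds shown alone.

Three compounds share one core and differ only in the ring that sits on the thiocarbonyl carbon. Compound 1 `Cc1ccnc(/C(N)=N/NC(=S)N2CCSCC2)c1` carries a thiomorpholin-4-yl there, and in a functional assay on MCF7 cells (Homo sapiens) for cytotoxicity, read by MTT assay, with a stated time of 72 h, tested at 10 uM (on this read-out lower numbers stand for less inhibition of growth and higher numbers for more inhibition of growth at the one concentration tested), compound 1 gives 62.5%. Compound 2 `Cc1ccnc(/C(N)=N/NC(=S)N2CCCC2)c1` carries a pyrrolidin-1-yl instead; in this assay compound 2 gives 63.6%. Compound 3 `Cc1ccnc(/C(N)=N/NC(=S)N2CCCCCC2)c1` carries a third ring at the same place, and in this assay compound 3 gives 60.3%. The number of compound 2 lies within the usual scatter of both compound 1 and compound 3, so the three cannot be told apart on these measurements.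

Going by the values given here, the only measured step that changes this ring is a number 1.1 percentage points higher from compound 1 to compound 2 (within the scatter), a swap of one ring for another at the same place that left the number where it was.

Compound 4 `Cc1ccnc(/C(N)=N/NC(=S)N2CCCCC2)c1` is the next member of this set: piperidin-1-yl in place of pyrrolidin-1-yl on a thiocarbonyl carbon. This is again a swap of one ring for another on the thiocarbonyl carbon. Since the step of a number 1.1 percentage points higher from compound 1 to compound 2 (within the scatter) stayed inside the scatter, and compound 3 with yet another ring also sits close, the expected step of a number 1.6 percentage points lower from compound 2 to compound 4 (within the scatter) is none beyond the scatter. Compound 4 is therefore expected to give about 62% in this assay, most likely between 52% and 72%.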

Compound 4, percent growth inhibition at one concentration: 40.7%
Beside the measured number, compound 4's estimate is 21.3 percentage points above it; the measured number lies below the stated range.
By their numbers in this assay, from the lowest: compound 4; then compounds 3, 1 and 2 (each within the scatter of the next).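

This position is less forgiving than the first step suggested: in this assay, a number 22.9 percentage points lower from compound 2 to compound 4 (beyond the scatter), so exchanging the five-membered pyrrolidin-1-yl for the six-membered piperidin-1-yl does matter, even though neither ring has a hydrogen-bond donor, a hydrogen-bond acceptor or a net charge. The comparison with the thiomorpholin-4-yl ring points the same way, a number 21.8 percentage points lower from compound 1 to compound 4 (beyond the scatter), which sets the piperidin-1-yl apart from both of these rings and shows that the earlier closeness of the numbers did not mean any ring would serve equally well on the thiocarbonyl carbon. Nothing available here explains why this one ring gives such a different number.

From the compounds shown here alone, whether the loss is particular to the piperidin-1-yl remains open: a morpholin-4-yl or piperazin-1-yl ring, or an open-chain diethylamino group, would show how far it extends. Going by these compounds, these numbers also come from a single concentration, so how the compounds compare across a range of concentrations remains unknown.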